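Lengthening the chain and adding ring fluorine

The source may report more compounds than this note shows. Statements on the series, on what has been measured and on what is new or still open speak of the compounds shown alone.

In an assay on HEK293 cells for inhibition of acid ceramidase (Homo sapiens), with a stated time of 10 min (on this read-out lower numbers stand for stronger inhibition and higher numbers for weaker inhibition), compound 1 `O=C(NCCCc1ccccc1)n1c(=O)oc2ccccc21` gives 55 nM. Compound 2 `O=C(c1ccccc1)c1ccc2c(c1)oc(=O)n2C(=O)NCCCCc1ccccc1` gives 29 nM and compound 3 `O=C(NCCCCc1ccccc1)n1c(=O)oc2cc(F)ccc21` gives 31 nM, and both of these values lie within the scatter of compound 1, so the three measured compounds cannot be ordered. Compound 4 `O=C(NCCCCc1ccc(F)cc1)n1c(=O)oc2ccccc21` is not yet measured; it carries 4-fluorobenzyl in place of phenyl on a saturated chain carbon, three bonds along the chain from an amide-type nitrogen. Within the data shown here, no measured step bears directly on this change. Among the measured compounds shown here, the only measured step, a 1.1-fold higher number from compound 2 to compound 3 (0.03 log units; within the scatter), concerns the core rather than the chain and is within the scatter. Compound 4 is therefore expected to show a step of a 1.4-fold lower number from compound 1 to compound 4 (0.14 log units; within the scatter), not beyond the scatter. The estimate for compound 4 in this assay is 40 nM, with a range from 15 nM to 110 nM.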

Compound 4, half-maximal inhibitory concentration: 75 nM
Estimate against measurement, compound 4: 1.9-fold (0.27 log units) below; the range from low to high includes it.
By their numbers in this assay, from the lowest: compounds 2, 3, 1 and 4 (each within the scatter of the next, the first and the last beyond it).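

Among these compounds, the first change at this end of the molecule gives a 1.4-fold higher number from compound 1 to compound 4 (0.13 log units; within the scatter) in this assay and so stays within the scatter. Replacing phenyl with 4-fluorobenzyl at this place on the chain therefore leaves the read-out without a resolved change. No supporting evidence bears on this result.

The compounds shown do not separate the added chain carbon from the ring fluorine. On these data alone, whether a longer chain, or a chlorine or methoxy group in place of that fluorine, would move the number beyond the scatter also remains open.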